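Shortening the hydroxamate chain on compound 3

This account rests on a few compounds, and the source may have more. Where it says the series, first, only, none or still open, it means among the compounds named here.

Measured compounds in a functional assay on MCF7 cells (Homo sapiens) for inhibition, read by MTT assay, with a stated time of 72 h; a higher number here means a weaker inhibitor, a lower number a stronger inhibitor:
compound 1, `CNC(=O)CCCCCCCn1nc(-c2ccc3oc(N)nc3c2)c2c(N)ncnc21`, gives 7220 nM.
compound 2, `Nc1nc2cc(-c3nn(CCCCCCCCCC(=O)NO)c4ncnc(N)c34)ccc2o1`, reaches only the assay limit, > 50000 nM.
compound 3, `Nc1ncnc2c1c(-c1cnc3[nH]ccc3c1)nn2CCCCCCCCCC(=O)NO`, gives 23200 nM.

Compound 3 holds the highest of the two numbers recorded; its nearest neighbour is compound 1, and the gap between them lies beyond the scatter. The recorded steps run from compound 1 to compound 2, where an at least 6.9-fold higher number from compound 1 to compound 2 (0.84 log units; beyond the scatter), and from compound 2 to compound 3, where an at least 2.1-fold lower number from compound 2 to compound 3 (0.33 log units; beyond the scatter); the first of these touches the chain end, the second the aromatic group on the core, and compound 2 sits at the limit (the limit of > 50000 nM in this assay, at which 1 of the 3 values shown sits).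

Compound 4, `Nc1ncnc2c1c(-c1cnc3[nH]ccc3c1)nn2CCCCC(=O)NO`, is not yet measured. It differs from compound 3 by hydroxycarbamoyl in place of 5-(hydroxycarbamoyl)pentyl on a saturated chain carbon, four bonds along the chain from an aromatic nitrogen. Within the data shown here, no recorded step shortens the chain in this way, so the direction is uncertain; compound 4 is expected to stay in the same weak region, with a step of a 1.5-fold higher number from compound 3 to compound 4 (0.18 log units; within the scatter). The estimate for compound 4 in this assay is 35000 nM, ranging from 10000 nM to 100000 nM.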

Compound 4, half-maximal inhibitory concentration: > 150000 nM
Compound 4: only a limit was reported; the forecaster's own chance of this, stated with the estimate: 40%; middle value at least 4.2-fold (0.63 log units) from the limit.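

In this assay, replacing 5-(hydroxycarbamoyl)pentyl with hydroxycarbamoyl gives an at least 6.4-fold higher number from compound 3 to compound 4 (0.81 log units; beyond the scatter), the first step shown that alters chain length while keeping the hydroxycarbamoyl end and the aromatic group on the core. Among these compounds, at this position, then, chain length alone moves the result beyond the scatter, which the earlier steps could not show, as they changed the chain end and the aromatic group, and the shorter chain is the weaker of this pair. The value of compound 4 is a limit and not a number: the limit of > 150000 nM in this assay, at which 1 of the 4 values shown sits.

With only these two chain lengths carrying the hydroxycarbamoyl end on this core, the compounds shown do not tell whether the number changes gradually or sharply between them. From the compounds shown here alone, whether a longer chain, or a carboxylic acid in place of the hydroxycarbamoyl end, would give a lower number also stays open.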